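A few compounds are considered here, and "the series" means these few. Any claim that something is new, unique, unknown or untested is made for them only; others in the source may bear on it.

Compound 1 (`COC(=O)C[C@@H]1C[C@@H](O)[C@H](C)[C@H](c2ccccc2)N1`): 5400 nM
Compound 2 (`COC(=O)C[C@H]1C[C@H](O)[C@@H](C)[C@@H](c2ccc(C)cc2)N1`): "not active" (no number reported)

In a functional assay on MCF7 cells (Homo sapiens) for cytotoxicity, read by MTT assay (a lower number here means a stronger inhibitor, a higher number a weaker inhibitor), compound 2 has no number to stand on and is reported only as "not active" (no number reported) while compound 1 gives the sole figure so far (5400 nM). Compound 3 (`COC(=O)C[C@H]1C[C@H](O)[C@@H](C)[C@@H](c2ccc(F)cc2)N1`) carries fluoro in place of methyl on an aromatic carbon, para to a large group (fluoro in place of methyl on an aromatic carbon). Among the compounds with values here, no measured step guides this change. With compound 2 reported as "not active" (no number reported) only a small step toward stronger inhibition is expected in this assay and compound 3 may again yield no number. Compound 3 is estimated at 20000 nM with an expected range from 6000 nM to 60000 nM for a measured value.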

Compound 3, half-maximal inhibitory concentration: 18200 nM
Estimate against measurement, compound 3: 1.1-fold (0.04 log units) above, within the range that was stated.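

Within the data shown here, compound 2 has no number in this assay, so no step to compound 3 can be read. Nothing shown bears on the reason for this result. The compounds shown leave open how far methyl and fluoro differ in this assay.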